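The compounds below may be only part of what the source reports. "The series", "measured", "known", "first", "only" and "open" are said of these compounds alone.

Of the compounds shown here, two sharing one core have been measured so far. In a functional assay on DU-145 cells (Homo sapiens) for antiproliferative activity, read by fluorescence and propidium iodide staining, with a stated time of 96 h (a higher number here means a weaker inhibitor, a lower number a stronger inhibitor), compound 1 `CC(O)(CS(=O)(=O)c1ccccc1C(F)(F)F)C(=O)Nc1cc(C(F)(F)F)cc(C(F)(F)F)c1` gives 11000 nM as its half-maximal inhibitory concentration, and compound 2 `CC(O)(CS(=O)(=O)c1cccc(OC(F)(F)F)c1)C(=O)Nc1cc(C(F)(F)F)cc(C(F)(F)F)c1` gives 14100 nM on the same read-out. Compound 2 thus stands together with compound 1, as these two numbers lie within the usual scatter of each other. Compound 3 `CC(O)(CS(=O)(=O)c1ccccc1OC(F)(F)F)C(=O)Nc1cc(C(F)(F)F)cc(C(F)(F)F)c1` is still unmeasured and has the same atoms as compound 2, joined differently. It carries 2-(trifluoromethoxy)phenyl in place of 3-(trifluoromethoxy)phenyl on a sulfonyl sulfur, a change counted as 2-(trifluoromethoxy)phenyl in place of 3-(trifluoromethoxy)phenyl on a sulfonyl sulfur here. For the measured compounds named here, only one measured step bears on this change: a 1.3-fold higher number from compound 1 to compound 2 (0.11 log units; within the scatter) on that same sulfonyl sulfur. Going by the values given here, this is thin evidence, and no measured pair yet shows the trifluoromethoxy group changing place alone. No step beyond the scatter is therefore expected in this assay and the estimated step is a 1.1-fold lower number from compound 2 to compound 3 (0.05 log units; within the scatter) for this swap. In this assay compound 3 is expected at 12500 nM with an estimated range from 5500 nM to 28000 nM around it.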

Compound 3, half-maximal inhibitory concentration: 12900 nM
The estimate for compound 3 lay 1.0-fold (0.01 log units) below the measured number; the measured number falls inside the stated range.
By their numbers in this assay, from the lowest: compounds 1, 3 and 2 (each within the scatter of the next).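

Moving the trifluoromethoxy group from 3-(trifluoromethoxy)phenyl to 2-(trifluoromethoxy)phenyl on the sulfonyl sulfur gives a 1.1-fold lower number from compound 2 to compound 3 (0.04 log units; within the scatter) in this assay, the first measured pair in which this group changes place alone. The same compound also opens a second comparison, trifluoromethoxy in place of trifluoromethyl on an aromatic carbon, and this exchange gives a 1.2-fold higher number from compound 1 to compound 3 (0.07 log units; within the scatter). Neither the change of place nor the change of group therefore moves the number beyond the scatter among these three compounds, and no measurement shown here offers an explanation for this.

As far as these compounds go, what remains open is whether a group of a different kind on this aromatic ring, such as an amine or a carboxylic acid, or a plain saturated chain in place of the whole ring on the sulfonyl sulfur, would give a step beyond the scatter. All three compounds also share the rest of the core, so they say nothing about how a change elsewhere, for example at the hydroxyl group or the amide, would affect the number.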